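The source may report more compounds than this note shows. Statements on the series, on what has been measured and on what is new or still open speak of the compounds shown alone.

Compound 1 `COc1cc(/C=C/C(=O)c2cccc(-c3cccc(F)c3)c2)ccc1O` gives 6740 nM
Compound 2 `COc1ccc(/C=C/C(=O)c2cccc(-c3cccc(F)c3)c2)cc1` gives 4510 nM

Both numbers come from a functional assay on SW480 cells (Homo sapiens) for cytotoxicity, read by sulforhodamine B assay, with a stated time of 48 h (on this read-out higher numbers stand for weaker inhibition and lower numbers for stronger inhibition), and lie within the usual scatter of each other, so compound 2 stands level with compound 1 and neither can be ranked ahead of the other. Compound 3 `COc1ccc(/C=C/C(=O)c2cccc(-c3cccc(F)c3)c2)cc1OC` differs from compound 2 by a single change, methoxy in place of hydrogen on an aromatic carbon in all, which in words is methoxy in place of hydrogen on an aromatic carbon, ortho to a methoxy group and meta to a large group. Going by the values given here, no measured pair differing in one place is available, so the data do not show directly what this change does. Among the compounds with values here, the only guide is how close compound 1 at 6740 nM lies to compound 2 at 4510 nM in the same test. On that limited basis, no step beyond the scatter is expected in this assay and no firm direction can be given. The expected move is a 1.1-fold higher number from compound 2 to compound 3 (0.04 log units; within the scatter) and would stay within the scatter. For compound 3 the estimated value is 5000 nM with an expected range from 2000 nM to 12000 nM in this test.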

Compound 3, half-maximal inhibitory concentration: 2970 nM
For compound 3 the middle estimate is 1.7-fold (0.23 log units) above the measured one; low and high end bracket the measured number.
By their numbers in this assay, from the lowest: compounds 3, 2 and 1 (each within the scatter of the next, the first and the last beyond it).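

In this assay, going by these compounds alone, methoxy in place of hydrogen on an aromatic carbon, ortho to a methoxy group and meta to a large group, gives a 1.5-fold lower number from compound 2 to compound 3 (0.18 log units; within the scatter) and so shows that this position carries the added methoxy with no step that can be told from the scatter. Methyl in place of hydrogen on an oxygen on an aromatic ring gives a 2.3-fold lower number from compound 1 to compound 3 (0.36 log units; beyond the scatter) and is the only step here beyond the scatter, which makes capping that oxygen a modest gain in this test, seen in this one pair alone. Nothing measured alongside these numbers bears on why either step has its size.

The compounds shown leave open whether a different group at this position, such as chlorine, an amine, a carboxylic acid or a longer chain like ethoxy, would give a step beyond the scatter. They also leave open whether replacing the fluoro group of the shared core with a nitrile or a trifluoromethyl group would change the number in this test.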